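The source may hold more compounds than are shown below. What is called first, only, known or untested is meant among the compounds shown, and "the series" means these compounds.

Within the data shown here, compound 3 `CCn1c(C(=O)N(CCC#N)CCC#N)ccc1C(CC)(CC)c1ccc(OCC(O)C(C)(C)C)c(C)c1` holds the middle place among the three measured members. In an assay on HL-60 cells for agonist activity at vitamin D3 receptor (Homo sapiens), read by microscopy, with a stated time of 96 h (a lower number here means that less compound is needed, a higher number that more compound is needed for the effect), compound 3 gives 97 nM. Compound 1 `CCOC(=O)CN(C)C(=O)c1ccc(C(CC)(CC)c2ccc(OCC(O)C(C)(C)C)c(C)c2)n1CC` gives 210 nM in this assay, and compound 2 `CCn1c(C(=O)NCCN)ccc1C(CC)(CC)c1ccc(OCC(O)C(C)(C)C)c(C)c1` gives 10 nM. The steps into compound 3 are a 2.2-fold lower number from compound 1 to compound 3 (0.34 log units; beyond the scatter) and a 9.7-fold higher number from compound 2 to compound 3 (0.99 log units; beyond the scatter).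

Compound 4 `C#CC(C)OC(=O)c1ccc(C(CC)(CC)c2ccc(OCC(O)C(C)(C)C)c(C)c2)n1CC` differs from compound 3 at the carbonyl carbon: a group of 5 heavy atoms (4 carbon, 1 oxygen; no ring) in place of a group of 9 heavy atoms (6 carbon, 3 nitrogen; no ring), on a carbonyl carbon. Among the measured compounds shown here, no measured step swaps the whole group on that carbonyl for an oxygen-linked one, so the nearest guide is the modest step of a 2.2-fold lower number from compound 1 to compound 3 (0.34 log units; beyond the scatter), which exchanged one neutral, donor-free group for another at the same carbonyl. The large step of a 21-fold lower number from compound 1 to compound 2 (1.32 log units; beyond the scatter) came with a group bearing a free amine, which compound 4 lacks. A change of modest size in this assay is therefore expected, direction uncertain, as a 1.5-fold higher number from compound 3 to compound 4 (0.19 log units; within the scatter). Compound 4 is estimated at 150 nM in this assay, with a range from 30 nM to 700 nM.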

Compound 4, half-maximal effective concentration: 200 nM
For compound 4 the middle estimate is 1.3-fold (0.12 log units) below the measured one; measured number inside the range.
By their numbers in this assay, from the lowest: compound 2; then compound 3; then compounds 4 and 1 (each within the scatter of the next).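

With (1-methylprop-2-yn-1-yl)oxy on the carbonyl carbon, a 1.1-fold lower number from compound 1 to compound 4 (0.02 log units; within the scatter) shows that in this assay this oxygen-linked group and the nitrogen-linked ((ethoxycarbonyl)methyl)(methyl)amino group cannot be told apart. The same group gives a 2.1-fold higher number from compound 3 to compound 4 (0.31 log units; beyond the scatter), so the two groups without hydrogen-bond donors in compound 1 and compound 3 do not define a single level at this position. The step of a 20-fold higher number from compound 2 to compound 4 (1.30 log units; beyond the scatter) extends the large gap already seen with (2-aminoethyl)amino to an oxygen-linked group, and compound 2 remains the only compound shown with a free amine.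

Nothing available gives a reason for these steps. Whether the free amine itself accounts for the low number of compound 2 remains open, as the compounds shown include no 3-aminopropylamino or 2-(dimethylamino)ethylamino group on this carbonyl carbon.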